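Working notes: step from compound 3 to compound 4

A few compounds are considered here, and "the series" means these few. Any claim that something is new, unique, unknown or untested is made for them only; others in the source may bear on it.

Measured in a functional assay on HL-60 cells (Homo sapiens) for cytotoxicity, read by MTT assay, with a stated time of 24 h; on this read-out higher numbers stand for weaker inhibition and lower numbers for stronger inhibition:
compound 1 `Clc1ccccc1-c1nnc(SCCCN2CCN(c3ccccn3)CC2)[nH]1` — > 300000 nM, a limit of the assay
compound 2 `CC(C)(C)c1ccc(-c2nn(CCCN3CCN(c4cccc(Cl)c4)CC3)c(=S)[nH]2)cc1` — > 300000 nM, a limit of the assay
compound 3 `Cc1ccc(-c2nn(CCCN3CCN(c4cccc(Cl)c4)CC3)c(=S)[nH]2)cc1` — > 300000 nM, a limit of the assay

Compound 3 gives > 300000 nM in this assay, which is a limit and not a number. Among the compounds with values here, the one paired step among the measured compounds, a step that the two limits leave unreadable from compound 2 to compound 3, cannot be read in size because of the limit of > 300000 nM in this assay, at which 3 of the 3 values shown sit. Within the data shown here, no compound in the set has a numeric value, so no measured step with a readable size exists to bear on the next change.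

Compound 4 `S=c1[nH]c(-c2ccc(Cl)cc2)nn1CCCN1CCN(c2cccc(Cl)c2)CC1` differs from compound 3 by chloro in place of methyl on an aromatic carbon. With every measured value sitting at the limit, the set gives no ground for expecting a step in either direction beyond the scatter, and the step is expected to be a step that the limit leaves unreadable from compound 3 to compound 4, most likely again not readable because of the limit of > 300000 nM in this assay, at which 3 of the 3 values shown sit.

Compound 4 is therefore estimated at 400000 nM in this assay, within a range from 150000 nM to 2000000 nM, with the expectation that the assay will again report only a limit for compound 4 rather than a number.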

Compound 4, half-maximal inhibitory concentration: 6670 nM
Beside the measured number, compound 4's estimate is 60-fold (1.78 log units) above it; measured number outside the range, below it.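

In this assay, within the data shown here, the aromatic carbon para to a large group is the first place where one change gives a step of readable scale: going from 4-methylphenyl to 4-chlorophenyl gives an at least 44-fold lower number from compound 3 to compound 4 (1.65 log units; beyond the scatter), and chloro in place of tert-butyl at the same carbon gives an at least 44-fold lower number from compound 2 to compound 4 (1.65 log units; beyond the scatter). Compound 4 is the only compound shown with a number, so exchanging one carbon for one chlorine at this place is enough to bring the series off the limit, whereas the earlier step between tert-butyl and methyl cannot be read. Both new steps give only a minimum size, and their full size stays unknown because compound 2 and compound 3 stand at the ceiling: the limit of > 300000 nM in this assay, at which 3 of the 4 values shown sit.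

The compounds shown leave open whether this step is particular to chloro or would also appear with fluoro, bromo, methoxy or a nitrile at the same carbon. They also leave open whether the number for compound 4 would hold with a longer chain between the shared core and the amine-bearing ring.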